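A few compounds are considered here, and "the series" means these few. Any claim that something is new, unique, unknown or untested is made for them only; others in the source may bear on it.

Measured in a functional assay on MT4 cells (Homo sapiens) for cytotoxicity, read by MTT assay; a lower number here means that less compound is tolerated, a higher number that more compound is tolerated:
- Compound 1 `Cc1c(O)nc(SCc2ccc(C#N)cc2)nc1Cc1c(Cl)cccc1Cl`: > 60000 nM
- Compound 2 `Cc1c(O)nc(SCc2ccc(C#N)cc2)nc1Cc1c(F)cccc1F`: > 65000 nM
- Compound 3 `COc1ccc(CCCSc2nc(O)c(C)c(Cc3c(Cl)cccc3Cl)n2)cc1`: 1000 nM

Compound 1 has no exact number, only a limit of > 60000 nM. Compound 2 also has only a limit, > 65000 nM. Compound 3 alone gives an exact number, 1000 nM.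

Compound 4 `Cc1c(O)nc(SCc2cccc(C#N)c2)nc1Cc1c(Cl)cccc1Cl` has the same atoms as compound 1, joined differently: 3-cyanophenyl in place of 4-cyanophenyl on a saturated chain carbon bound to a sulfur. This places 3-cyanophenyl in place of 4-cyanophenyl on a saturated chain carbon bound to a sulfur.

Going by the values given here, only one measured step bears on this, and only loosely. That step, a step that the two limits leave unreadable from compound 1 to compound 2, puts 2,6-difluorophenyl in place of 2,6-dichlorophenyl, at a different place, and its size cannot be read. With no measured size to go on, no change beyond the usual scatter is expected in this assay. The expected step is an at least 1.2-fold lower number from compound 1 to compound 4 (0.07 log units; that floor lies within the scatter). Compound 3, at 1000 nM, keeps the lower end of the range wide. For compound 4 the estimated value is 50000 nM, with an expected range from 15000 nM to 100000 nM.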

Compound 4, half-maximal cytotoxic concentration: > 60000 nM
Compound 4 ended at the assay's limit; the forecaster's own chance of this, stated with the estimate: 65%; at least 1.2-fold (0.07 log units) between middle value and limit.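

Compound 1 and compound 4 both end at a limit of the assay rather than at a number, so no step between them can be read: the limit of > 60000 nM in this assay, at which 2 of the 4 values shown sit.

The compounds shown leave open whether 3-cyanophenyl in place of 4-cyanophenyl changes the result in this assay at all.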